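From 4-hydroxyphenyl to 2-phenylethenyl

A few compounds are considered here, and "the series" means these few. Any claim that something is new, unique, unknown or untested is made for them only; others in the source may bear on it.

Compound 1 `CCOc1ccc(/C=N/NC(=O)COc2cccc3ccccc23)cc1O`: 6.23 ug/mL
Compound 2 `O=C(COc1cccc2ccccc12)N/N=C/c1ccc(O)cc1`: 26.5 ug/mL
Compound 3 `C/C(=N\NC(=O)COc1cccc2ccccc12)c1ccccc1`: 105 ug/mL

These numbers come from a single cell test (an ADME assay on MT4 cells (Homo sapiens) for cytotoxicity, read by MTT assay, with a stated time of 4 days; on this read-out higher numbers stand for lower toxicity in this test and lower numbers for higher toxicity in this test). Compound 2 (26.5 ug/mL) stands in the middle of the three: compound 3 is higher and compound 1 is lower, each by a gap beyond the usual scatter.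

Compound 4 (`O=C(COc1cccc2ccccc12)N/N=C/C=C/c1ccccc1`) has not yet been measured. It has 2-phenylethenyl in place of 4-hydroxyphenyl on a carbon with a double bond to nitrogen. Within the data shown here, no two measured compounds differ in just one place, so no direct step can guide the expectation.

The only hint is indirect. Compound 3 (105 ug/mL) has no hydroxy group and gives the highest number. Compound 1 (6.23 ug/mL) has one and gives the lowest. Compound 3 also differs from compound 2 in other ways, and three compounds are few, so this hint is weak.

A small rise, within the scatter, is therefore what is expected in this assay, and the estimated step is a 1.3-fold higher number from compound 2 to compound 4 (0.12 log units; within the scatter) here. For compound 4 the estimate is 35 ug/mL, with an expected range from 11 ug/mL to 100 ug/mL.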

Compound 4, half-maximal cytotoxic concentration: 82.7 ug/mL
Estimate against measurement, compound 4: 2.4-fold (0.37 log units) below; measured number inside the range.
By their numbers in this assay, from the lowest: compound 1; then compound 2; then compounds 4 and 3 (each within the scatter of the next).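

In this assay, a 3.1-fold higher number from compound 2 to compound 4 (0.49 log units; beyond the scatter) is the only step shown that changes a single place, and it lies beyond the scatter, so the group on a carbon with a double bond to nitrogen does affect the read-out, here in the direction of lower toxicity in this test. The swap changes two things at once: the hydroxy group of 4-hydroxyphenyl leaves, and 2-phenylethenyl brings a double bond outside aromatic rings, while one six-membered aromatic ring of carbon stays in both compounds. No measurement shown here gives a reason for the rise, so the step records an outcome and not a mechanism.

The compounds shown leave open which of those two changes carries the step, a question that 2-phenylethyl, the same group without its double bond, would help to separate. They also leave open how this position responds to a ring bearing an amine, as in 4-aminophenyl, or to a carboxylic acid or a longer chain in the same place.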